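Stripping the amino acid from a terpenoid quinone

This account rests on a few compounds, and the source may have more. Where it says the series, first, only, none or still open, it means among the compounds named here.

Among the compounds with values here, compound 1 `CC1=CCC[C@H]2[C@](C)(CC3=CC(=O)C=C(N[C@@H](C(=O)O)C(C)C)C3=O)[C@@H](C)CC[C@]12C` stands lowest of the two numbers so far: in a functional assay on K562 cells (Homo sapiens) for cytotoxicity, read by MTT assay, with a stated time of 72 h (a lower number here means a stronger inhibitor, a higher number a weaker inhibitor), compound 1 gives 7780 nM, while compound 2 `C[C@H](NC1=CC(=O)C=C(C(C)(C)C)C1=O)C(=O)O` gives 77600 nM, a gap beyond the usual scatter. Compound 3 `CC1=CCC[C@H]2[C@](C)(CC3=CC(=O)C=CC3=O)[C@@H](C)CC[C@]12C` is compound 1 with hydrogen in place of (1-carboxy-2-methylpropyl)amino on a double-bonded ring carbon. Within the data shown here, no such step has yet been measured here. The change is expected to cost potency modestly, a 1.5-fold higher number from compound 1 to compound 3 (0.19 log units; within the scatter), though a step within the scatter would not surprise. Compound 3 is thus estimated at 12000 nM, with a likely range from 3000 nM to 50000 nM.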

Compound 3, half-maximal inhibitory concentration: 17100 nM
Compound 3: middle estimate off by 1.4-fold (0.15 log units), on the low side; measured number inside the range.
By their numbers in this assay, from the lowest: compound 1; then compound 3; then compound 2.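

In this assay, replacing (1-carboxy-2-methylpropyl)amino with hydrogen on the double-bonded ring carbon gives a 2.2-fold higher number from compound 1 to compound 3 (0.34 log units; beyond the scatter). This position therefore tolerates the loss of the whole group at a modest cost, though one beyond the scatter, and activity on these cells does not depend on the group. Nothing measured here explains the size of this step. From the compounds shown here alone, it remains open whether a plain amine, a methoxy group or a shorter amino acid chain on this carbon would match the number of compound 1, and whether a longer chain would lower it further.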